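Nitro substitution on the furan hydrazone of compound 3

The source may hold more compounds than are shown below. What is called first, only, known or untested is meant among the compounds shown, and "the series" means these compounds.

Compound 3 `C(=N/N(Cc1ccccc1)Cc1ccccc1)\c1ccco1` gives 1100 nM in an assay on liver (Sus scrofa) for inhibition of glucose-6-phosphatase catalytic subunit 1 (Homo sapiens), using microsomes (a higher number here means a weaker inhibitor, a lower number a stronger inhibitor), the highest of the two numbers available. Compound 1 `COc1ccc(/C=N/N(Cc2ccccc2)Cc2ccccc2)cc1` gives 220 nM, and the step of a 5.0-fold higher number from compound 1 to compound 3 (0.70 log units; beyond the scatter) is modest. Compound 2 `COc1ccccc1/C=N/N(Cc1ccccc1)Cc1ccccc1` reaches only a limit of the assay, > 100000 nM. The step of an at least 450-fold higher number from compound 1 to compound 2 (2.65 log units; beyond the scatter) is large, as is an at least 90-fold lower number from compound 2 to compound 3 (1.95 log units; beyond the scatter); both turn on where the methoxy sits on the phenyl ring and say nothing about substitution on the furan ring. Compound 4 `O=[N+]([O-])c1ccc(/C=N/N(Cc2ccccc2)Cc2ccccc2)o1` differs from compound 3 by nitro in place of hydrogen on an aromatic carbon. Going by the values given here, no measured step bears directly on this change, since none of the three measured compounds carries a nitro group or any substituent on the furan. The basis for prediction is thus thin, and no step beyond the scatter is expected in either direction. For compound 4 the estimate in this assay is 800 nM, within 150 nM to 4000 nM. The step of a 1.4-fold lower number from compound 3 to compound 4 (0.14 log units; within the scatter) expected here is small.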

Compound 4, half-maximal inhibitory concentration: > 100000 nM
Compound 4 was reported as a limit; the forecaster's own chance of this, stated with the estimate: 5%; middle value at least 120-fold (2.09 log units) away from the limit.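

On an aromatic carbon next to the ring oxygen, furan-2-yl to 5-nitrofuran-2-yl is the first change shown on the furan itself, and in this assay it gives an at least 90-fold higher number from compound 3 to compound 4 (1.95 log units; beyond the scatter). Substitution at this carbon therefore matters in this series, and an at least 450-fold higher number from compound 1 to compound 4 (2.65 log units; beyond the scatter) places the 5-nitrofuran-2-yl group well behind the 4-methoxyphenyl group. Neither compound 2 nor compound 4 gives a number, and the step between them cannot be read: the limit of > 100000 nM in this assay, at which 2 of the 4 values shown sit.

Only hydrogen and nitro are shown at this carbon, and whether the loss belongs to nitro alone or to any group placed there remains open. A methyl group, an amine or a carboxylic acid at the same carbon would separate these readings, and a nitro group on the phenyl ring of compound 1 would test whether the result carries over from the furan.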